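Isopropyl for isobutyl on the amino-acid ester arm

A few compounds are considered here, and "the series" means these few. Any claim that something is new, unique, unknown or untested is made for them only; others in the source may bear on it.

Measured so far:
- compound 1 `COC(=O)[C@H](CC(C)C)NC(=O)c1ccc(/C=C2\SC(=O)N(CC(=O)NOCc3ccccc3)C2=O)cc1` — in a functional assay on MRC5 cells (Homo sapiens) for inhibition, read by microscopy and resazurin assay, with a stated time of 72 h (on this read-out higher numbers stand for weaker inhibition and lower numbers for stronger inhibition), compound 1 gives > 128000 nM
- compound 2 `C=CCONC(=O)CN1C(=O)S/C(=C\c2cccc(C(=O)N[C@@H](CC(C)C)C(=O)OC)c2)C1=O` — in this assay compound 2 gives > 128000 nM

Both readings are limits of the assay and not numbers. Among the compounds with values here, compound 1 stands only at a limit, and the one other value shown is likewise a limit; both sit at the limit of > 128000 nM in this assay, at which 2 of the 2 values shown sit. Within the data shown here, no pair of measured compounds differs in a single place, so no measured step is available.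

Compound 3 `COC(=O)[C@@H](NC(=O)c1ccc(/C=C2\SC(=O)N(CC(=O)NOCc3ccccc3)C2=O)cc1)C(C)C` is the next candidate. It differs from compound 1 by isopropyl in place of isobutyl on a saturated chain carbon bound to an amide-type nitrogen and a carbonyl carbon. With compound 1 at a limit, no step beyond the scatter is expected in this assay; the step from compound 1 to compound 3 is estimated as a step that the limit leaves unreadable from compound 1 to compound 3. For compound 3 the expected value in this assay is 150000 nM, within a range from 60000 nM to 400000 nM, most likely again reported only as a limit.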

Compound 3, half-maximal inhibitory concentration: > 128000 nM
Compound 3: a limit, no number; the forecaster's own chance of this, stated with the estimate: 85%; the middle value does not contradict the limit.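

No step can be read between compound 1 and compound 3 in this assay, as both stand only at a limit: the limit of > 128000 nM in this assay, at which 3 of the 3 values shown sit. The compounds shown leave open whether any structure in this series gives a number rather than a limit in this assay.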